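Swapping a Nonyl Ester for a Dibutyl Carbamate

The source may hold more compounds than are shown below. What is called first, only, known or untested is meant among the compounds shown, and "the series" means these compounds.

Measured compounds:
compound 1 `CCCCCCCCCC(=O)OCC1CN(C(=O)c2cc(OC)c(OC)c(OC)c2)CCN1C(=O)c1cc(OC)c(OC)c(OC)c1` — 2820 nM
compound 2 `COc1cc(C(=O)N2CCN(C(=O)c3cc(OC)c(OC)c(OC)c3)C(COC(=O)C(C)(C)C)C2)cc(OC)c1OC` — 100 nM; 100 nM; 120 nM (3 entries)
compound 3 `CCC(CC)NC(=O)OCC1CN(C(=O)c2cc(OC)c(OC)c(OC)c2)CCN1C(=O)c1cc(OC)c(OC)c(OC)c1` — 130 nM

All three share the same core and differ only in the group attached through the carbonyl carbon of the ester or carbamate. In a functional assay (Oryctolagus cuniculus) for inhibition of platelet-activating factor receptor (Cavia porcellus) (on this read-out lower numbers stand for stronger inhibition and higher numbers for weaker inhibition), compound 1 gives 2820 nM and stands highest among the single numbers shown, that is, it is the weakest inhibitor of the set. Compound 3, the nearest to it, gives 130 nM, and the measured step of a 22-fold lower number from compound 1 to compound 3 (1.34 log units; beyond the scatter) shows how much a carbamate in place of the long ester moves the result. Compound 2 was measured three times, (the several entries of compound 2 in this assay, 100 nM; 100 nM; 120 nM (3 entries)), and its entries sit close to compound 3.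

Compound 4 `CCCCN(CCCC)C(=O)OCC1CN(C(=O)c2cc(OC)c(OC)c(OC)c2)CCN1C(=O)c1cc(OC)c(OC)c(OC)c1` is the next candidate. Compared with compound 1 the change is dibutylamino in place of nonyl on a carbonyl carbon. Among the measured compounds shown here, the one measured step that bears on this is a 22-fold lower number from compound 1 to compound 3 (1.34 log units; beyond the scatter), where a carbamate nitrogen replaced the chain at the same carbonyl carbon and the number fell strongly. A step of similar size and direction is therefore expected here, a 14-fold lower number from compound 1 to compound 4 (1.15 log units; beyond the scatter). Compound 4 is estimated at 200 nM, with a range from 60 nM to 700 nM.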

Compound 4, half-maximal inhibitory concentration: 1250 nM
The estimate for compound 4 lay 6.3-fold (0.80 log units) below the measured number; the whole stated range lies below it.
By their numbers in this assay, from the lowest: compound 3; then compound 4; then compound 1.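

Replacing nonyl with dibutylamino keeps the count at 9 heavy atoms, with one nitrogen taking the place of a carbon, yet this gives only a 2.3-fold lower number from compound 1 to compound 4 (0.35 log units; beyond the scatter) in this assay, so among these compounds, a carbamate at this carbonyl carbon does not by itself bring the large gain seen earlier. What is attached to the carbamate nitrogen matters as well, as exchanging (pentan-3-yl)amino for dibutylamino gives a 9.6-fold higher number from compound 3 to compound 4 (0.98 log units; beyond the scatter), so the strong drop seen with compound 3 goes with that particular amino group and not with the carbamate link as such. The data shown offer no measurement that explains why these two amino groups read so differently.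

From the compounds shown here alone, it remains open whether a single straight butylamino group on the same carbonyl carbon would read closer to compound 3 or to compound 4, which would help show whether having two chains on the nitrogen counts for more than their length. The effect of a shorter dimethylamino group, or of a ring amine such as piperidin-1-yl, at this carbonyl carbon is also unknown.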